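The compounds below may be only part of what the source reports. "The series", "measured", "known", "first", "only" and "open" are said of these compounds alone.

Compound 1 `CC(=O)N1N=C(c2ccc(-n3c(C)ccc3C)cc2)OC1c1ccccc1[N+](=O)[O-]` and compound 2 `Brc1ccc(-c2nnc(-c3ccc(-n4cccc4)cc3)o2)cc1` were both tested in an ADME assay on Vero cells (Chlorocebus sabaeus) for cytotoxicity, read by MTT assay, with a stated time of 72 h; a lower number here means a stronger inhibitor, a higher number a weaker inhibitor. In this assay compound 1 gives 175000 nM, and in the same assay compound 2 gives 260000 nM. Among the measured compounds shown here, of the two numbers, the one for compound 2 is the higher, but the gap to compound 1 lies within the usual scatter of repeated measurements, so neither compound can be called the stronger or the weaker inhibitor on this evidence; both sit at the weak end of what such an assay reports.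

Compound 3 `c1ccc(-c2nnc(-c3ccc(-n4cccc4)cc3)o2)cc1` has not been measured. It differs from compound 2 in one place: hydrogen in place of bromo on an aromatic carbon. A hydrogen stands where compound 2 carries a bromo group.

For the measured compounds named here, no pair of measured compounds shares this change, so nothing in the data fixes its size. The expectation for this assay is a step from compound 2 to compound 3 that stays within the scatter, if anything drifting toward a higher number, estimated as a 1.2-fold higher number from compound 2 to compound 3 (0.06 log units; within the scatter). Compound 3 is therefore expected to give about 300000 nM, within a range from 150000 nM to 600000 nM.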

Compound 3, half-maximal inhibitory concentration: 250000 nM
Estimate against measurement, compound 3: 1.2-fold (0.08 log units) above; the measured number falls inside the stated range.
By their numbers in this assay, from the lowest: compounds 1, 3 and 2 (each within the scatter of the next).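

Compounds 1 and 2 differ in more than one place, so they could not show what any single group contributes; compound 2 and compound 3 differ in one place only, and that allows a direct reading. In this assay, going from 4-bromophenyl to phenyl, with hydrogen in place of bromo on an aromatic carbon para to a large group, gives a 1.0-fold lower number from compound 2 to compound 3 (0.02 log units; within the scatter), so at this position the bromo group makes no difference that can be told from ordinary measurement scatter, and the pair stays at the weak end of what this kind of assay reports. No measurement shown here explains why this step is so small.

What an amine, a carboxylic acid or a longer chain on this same carbon would do to the number remains open, as the compounds shown carry only bromo or hydrogen there. On these data alone, whether hydrogen in place of bromo would also leave the number unmoved on a different core, such as the core of compound 1, remains open as well.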